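The compounds below may be only part of what the source reports. "The series", "measured", "known", "first", "only" and "open" are said of these compounds alone.

Working notes on the series. The shared core carries a side group on the ring with one nitrogen; compound 1 `CNC(=O)/C=C/c1ccncc1-c1ccc2cccnc2c1` and compound 3 `CNC(=O)/C=C/c1ccncc1-c1ccc2c(ccn2C)c1` show what that group does in an assay on a protein complex for inhibition of CDK8/Cyclin C (Homo sapiens), with a stated time of 1 h; on this read-out lower numbers stand for stronger inhibition and higher numbers for weaker inhibition: compound 1 gives 1760 nM, compound 3 gives 77.6 nM. Compound 2 `NNC(=O)COc1ccncc1-c1ccc2ccccc2c1` has in this assay the entry "not determined" (no result reported), so compound 2 stands nowhere on these numbers, since no result was reported for it in this assay. Compound 4 `O=C(/C=C/c1ccncc1-c1ccc2ccccc2c1)NC1CC1` differs from compound 2 by 2-(cyclopropylcarbamoyl)ethenyl in place of (aminocarbamoyl)methoxy on an aromatic carbon. With no value for compound 2, the size and direction of the step cannot be stated in this assay; compound 4 is judged only from the two measured compounds, whose side groups resemble its own. For compound 4 a value near 500 nM is expected, within a range from 100 nM to 3000 nM.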

Compound 4, half-maximal inhibitory concentration: 40.1 nM
Beside the measured number, compound 4's estimate is 12-fold (1.10 log units) above it; measured number outside the range, below it.
By their numbers in this assay, from the lowest: compounds 4 and 3 (each within the scatter of the next); then compound 1.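

In this assay, among the compounds shown here, compound 2 has no number, so no step to compound 4 can be read. The compounds shown leave open how much of the value of compound 4 goes with its 2-(cyclopropylcarbamoyl)ethenyl group. Nothing available bears on a cause for this result.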